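The compounds below may be only part of what the source reports. "The series", "measured", "known", "first", "only" and "open" are said of these compounds alone.

In a functional assay on the whole organism for antagonist activity, with Mus musculus as the target (a lower number here means that less compound is needed, a higher number that more compound is needed for the effect), compound 1 `CC(=O)N(C)C(C)C#CCn1ccnc1` gives > 100 mg/kg, which is a limit of the assay and not a number. Two relatives carry one extra methyl on the shared core. Compound 2 `CC(=O)N(C)C(C)C#CCn1cncc1C` gives 80 mg/kg, and compound 3 `CC(=O)N(C)C(C)C#CCn1ccnc1C` gives 11.8 mg/kg. Seen as steps, these are an at least 1.2-fold lower number from compound 1 to compound 2 (0.09 log units; that floor lies within the scatter) and an at least 8.4-fold lower number from compound 1 to compound 3 (0.92 log units; beyond the scatter), and each places methyl in place of hydrogen on an aromatic carbon.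

Compound 4 `CC(=O)N(C)CC#CCn1ccnc1` differs from compound 1 elsewhere: hydrogen in place of methyl on a saturated chain carbon bound to an amide-type nitrogen and a triple-bonded carbon. For the measured compounds named here, no measured step covers a change at this place, so the two steps above bear on it only loosely. They show that a single methyl can matter in this small set, as with compound 3 in an at least 8.4-fold lower number from compound 1 to compound 3 (0.92 log units; beyond the scatter), but also that it may not clearly do so, as with compound 2 in an at least 1.2-fold lower number from compound 1 to compound 2 (0.09 log units; that floor lies within the scatter). Neither fixes a direction for removing a methyl from the chain, so no clear step beyond the scatter is expected in this assay. The expected outcome is a step that the limit leaves unreadable from compound 1 to compound 4. A reading that is again only a limit would be no surprise. For compound 4 the estimate is 120 mg/kg, with an expected range from 40 mg/kg to 350 mg/kg.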

Compound 4, dose for half-maximal effect: > 100 mg/kg
Compound 4: no number, only a limit; the forecaster's own chance of this, stated with the estimate: 55%; the middle value does not contradict the limit.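

In this assay, for the compounds shown here, compound 1 and compound 4 each end at a limit of the assay and not at a number, so no step between them can be read: the limit of > 100 mg/kg in this assay, at which 2 of the 4 values shown sit.

The compounds shown leave open whether hydrogen in place of methyl on this saturated chain carbon changes the dose needed at all.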